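The source may hold more compounds than are shown below. What is called first, only, known or untested is meant among the compounds shown, and "the series" means these compounds.

Measured so far:
Compound 1, `COC(=O)[C@@]1(C)CCC=C2[C@@H]1CC[C@@H](C)[C@]2(C)Cc1c[nH]c2c(C)cccc12`, gives 26000 nM in a functional assay on WiDr cells (Homo sapiens) for inhibition, read by sulforhodamine B assay, with a stated time of 48 h; a lower number here means a stronger inhibitor of growth, a higher number a weaker inhibitor of growth.
Compound 2, `COC(=O)[C@@]1(C)CC[C@@H]2C3=C1CC[C@@H](C)[C@]3(C)C[C@@H]1c3ccccc3N[C@H]21`, gives 50000 nM in this assay.

Both numbers are high, meaning that neither compound holds back the growth of these cells strongly. Among the measured compounds shown here, the gap between compound 1 and compound 2 lies within the scatter of repeated measurements, so the two cannot be told apart on these numbers, and compound 2 stands level with the only other compound measured.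

Compound 3, `COC(=O)[C@@]1(C)CC[C@@H]2C3=C1CC[C@@H](C)[C@]3(C)C[C@@H]1c3cc(F)ccc3N[C@H]21`, has not yet been measured. Compared with compound 2 it carries fluoro in place of hydrogen on an aromatic carbon. The rest of the structure is unchanged.

For the measured compounds named here, no step between two measured compounds tells how such a swap has behaved, so the expectation rests only on the small size of the change. For compound 3 the expected step is a 1.3-fold lower number from compound 2 to compound 3 (0.10 log units; within the scatter), which is none beyond the scatter. Compound 3 is therefore estimated to give about 40000 nM in this assay, within a range from 15000 nM to 120000 nM.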

Compound 3, concentration for 50% growth inhibition: 32000 nM
Compound 3: middle estimate off by 1.3-fold (0.10 log units), on the high side, within the range that was stated.
By their numbers in this assay, from the lowest: compounds 1, 3 and 2 (each within the scatter of the next).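

This is the first pair shown that differs in one place only, so the swap can be read directly. Fluoro in place of hydrogen on this aromatic carbon, meta to a fused ring and para to a fused ring, gives a 1.6-fold lower number from compound 2 to compound 3 (0.19 log units; within the scatter) in this assay, so compound 2 and compound 3 cannot be told apart on these numbers. The position therefore accepts a fluoro with no change that can be told from the scatter, and nothing shown here bears on why.

Still open, on these data alone, is whether a different group on this same carbon, such as methoxy or an amine, would give a step beyond the scatter. Also open, as far as these compounds go, is how fluoro would behave on another carbon of that ring, or a carboxylic acid in place of the methyl ester.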